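The source may report more compounds than this note shows. Statements on the series, on what has been measured and on what is new or still open speak of the compounds shown alone.

Compound 2 `CCc1cc(=O)c2ccc(OC(C)C)c(CBr)c2o1` stands at a limit of the assay rather than at a number: in a functional assay on A549 cells (Homo sapiens) for antiproliferative activity, read by sulforhodamine B assay, with a stated time of 72 h (a higher number here means a weaker inhibitor of growth, a lower number a stronger inhibitor of growth), compound 2 gives > 30700 nM. Compound 1 `CCc1cc(=O)c2ccc(OC)c(CBr)c2o1` likewise reaches only a limit, giving > 33600 nM in this assay. For the measured compounds named here, the single measured step, a step that the two limits leave unreadable from compound 1 to compound 2, therefore cannot be read in size or direction. Compound 3 `CCc1cc(=O)c2ccc(OCC(C)C)c(CBr)c2o1` differs from compound 2 by isobutyl in place of isopropyl on an oxygen on an aromatic ring. No readable measured step bears on this change, so no step beyond the scatter is expected in this assay in either direction. Compound 3 is estimated at 40000 nM, with a range from 15000 nM to 150000 nM, which means an expected step that the limit leaves unreadable from compound 2 to compound 3.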

Compound 3, concentration for 50% growth inhibition: > 29400 nM
Compound 3: no number, only a limit; the forecaster's own chance of this, stated with the estimate: 85%; the middle value is on the limit's open side.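

In this assay compound 3 gives > 29400 nM, which is a limit, so the steps linking compound 1, compound 2 and compound 3 cannot be read. The compounds shown leave open whether changing the group on the oxygen alters growth inhibition at all.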